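From hydroxy to amino: compound 3 to compound 4

A few compounds are considered here, and "the series" means these few. Any claim that something is new, unique, unknown or untested is made for them only; others in the source may bear on it.

Measured in a functional assay on SK-HEP1 cells (Homo sapiens) for cytotoxicity, read by sulforhodamine B assay, with a stated time of 72 h; a higher number here means a weaker inhibitor, a lower number a stronger inhibitor:
- Compound 1 `OCC1=C(F)[C@@H](n2cnc3c(O)ncnc32)[C@H](O)[C@@H]1O`: > 100000 nM (a limit of the assay)
- Compound 2 `CNc1ncnc2c1ncn2[C@@H]1C(F)=C(CO)[C@@H](O)[C@H]1O`: 2760 nM
- Compound 3 `Nc1nc(O)c2ncn([C@@H]3C(F)=C(CO)[C@@H](O)[C@H]3O)c2n1`: > 100000 nM (a limit of the assay)

Compound 3 gives no true number, only a limit. It shares (the limit of > 100000 nM in this assay, at which 2 of the 3 values shown sit).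

Compound 4 `Nc1nc(N)c2ncn([C@@H]3C(F)=C(CO)[C@@H](O)[C@H]3O)c2n1` carries amino in place of hydroxy on an aromatic carbon, (amino in place of hydroxy on an aromatic carbon).

Among the compounds with values here, two measured steps bear on this change. The closer one swaps hydroxy for methylamino, and it is large: an at least 36-fold lower number from compound 1 to compound 2 (1.55 log units; beyond the scatter). The entering group there is methylamino rather than amino, so it is a guide and not an exact match. The other step adds the amino group that compound 3 and compound 4 share, but it says nothing about size: a step that the two limits leave unreadable from compound 1 to compound 3.

A clear move towards a lower number in this assay is therefore expected, though its size is uncertain. The expected change is an at least 10-fold lower number from compound 3 to compound 4 (1.00 log units; beyond the scatter). For compound 4 the estimate is 10000 nM, with an expected range from 1500 nM to 60000 nM.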

Compound 4, half-maximal inhibitory concentration: > 100000 nM
Compound 4: a limit, no number; the forecaster's own chance of this, stated with the estimate: 20%; middle value at least 10-fold (1.00 log units) away from the limit.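

Within the data shown here, compound 3 and compound 4 both end at a limit of the assay rather than a true number, so no step between them can be read in this assay: the limit of > 100000 nM in this assay, at which 3 of the 4 values shown sit.

From the compounds shown here alone, how far each compound lies beyond that limit, and whether amino in place of hydroxy changes anything here, stays open.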